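The source may report more compounds than this note shows. Statements on the series, on what has been measured and on what is new or still open speak of the compounds shown alone.

Measured compounds:
- compound 1, `CC#CC(CC(=O)O)c1ccc(OCc2ccc3nc(-c4ccc(C(F)(F)F)cc4)cn3c2)cc1`: 558 nM
- compound 2, `CC#CC(CC(=O)O)c1ccc(OCc2ccc3nc(-c4ccccc4C)cn3c2)cc1`: 389 nM
- compound 3, `CC#CC(CC(=O)O)c1ccc(OCc2ccc3nc(-c4ccc(C(C)C)cc4)cn3c2)cc1`: 528 nM

All three share one core and differ only in the aryl group on the five-membered ring of the fused system. In an assay on isolated protein for agonist activity at Free fatty acid receptor 1 (Homo sapiens) (a higher number here means that more compound is needed for the effect, a lower number that less compound is needed), compound 3 stands second highest of the three numbers; its nearest neighbour is compound 1 and its furthest is compound 2, and neither gap passes the scatter (a 1.1-fold lower number from compound 1 to compound 3 (0.02 log units; within the scatter), a 1.4-fold higher number from compound 2 to compound 3 (0.13 log units; within the scatter)).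

Compound 4, `CC#CC(CC(=O)O)c1ccc(OCc2ccc3nc(-c4ccc(C)cc4C)cn3c2)cc1`, is the next step from compound 3: 2,4-dimethylphenyl in place of 4-isopropylphenyl on an aromatic carbon. It carries the 2-methylphenyl pattern of compound 2 together with a second methyl in the position that compound 3 fills with isopropyl. For the measured compounds named here, the steps that bear on it are the aryl swaps already seen: a 1.4-fold lower number from compound 1 to compound 2 (0.16 log units; within the scatter) and a 1.4-fold higher number from compound 2 to compound 3 (0.13 log units; within the scatter), with a 1.1-fold lower number from compound 1 to compound 3 (0.02 log units; within the scatter) as the third. None of them moved this assay beyond the scatter, so for compound 4 no step beyond the scatter is expected in this assay, a 1.2-fold lower number from compound 3 to compound 4 (0.07 log units; within the scatter).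

Compound 4 is therefore estimated at 450 nM, with a range of 230 nM to 900 nM.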

Compound 4, half-maximal effective concentration: 316 nM
Compound 4: the middle estimate sits 1.4-fold (0.15 log units) above what was measured; the range from low to high includes it.
By their numbers in this assay, from the lowest: compounds 4, 2, 3 and 1 (each within the scatter of the next).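

In this assay, for the compounds shown here, methyl in place of hydrogen on the aryl group stays within the scatter (a 1.2-fold lower number from compound 2 to compound 4 (0.09 log units; within the scatter)), giving the first direct reading of a single added group on this ring. The wider swaps to 2,4-dimethylphenyl also stay within the scatter, from 4-isopropylphenyl (a 1.7-fold lower number from compound 3 to compound 4 (0.22 log units; within the scatter)) and from 4-(trifluoromethyl)phenyl (a 1.8-fold lower number from compound 1 to compound 4 (0.25 log units; within the scatter)), so no aryl change shown at this carbon of the five-membered aromatic ring gives a step beyond the scatter. (Nothing available explains this flat response).

Open, on these data alone, is whether the flat response holds for other kinds of substituent on this phenyl ring, such as an amine, a carboxylic acid or a longer alkyl chain. Also open, as far as these compounds go, is whether the aryl group at this position can be replaced by a saturated ring such as cyclohexyl.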